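The compounds below may be only part of what the source reports. "The series", "measured", "known", "first", "only" and "open" are said of these compounds alone.

Measured in a physicochemical assay for solubility; a higher number here means a more soluble compound, a lower number a less soluble compound:
- Compound 1 `CNC(=O)c1cc(C(=O)NC2CC2)cn(Cc2ccc(OC)cc2)c1=O`: >= 143 ug/mL (a limit)
- Compound 2 `CNC(=O)c1cc(C(=O)NC2CC2)cn(Cc2ccc(C)cc2)c1=O`: 24 ug/mL
- Compound 3 `CNC(=O)c1cc(C(=O)NC2CC2)cn(CC2CCCCC2)c1=O`: >= 148 ug/mL (a limit)

Compound 3 stands at >= 148 ug/mL, which is a limit and not a number. Compound 4 `CNC(=O)c1cc(C(=O)NC2CC2)cn(CC2CCCOC2)c1=O` carries oxan-3-yl in place of cyclohexyl on a saturated chain carbon bound to an aromatic nitrogen. The nearest measured changes replace the whole ring. One is an at least 6.1-fold higher number from compound 2 to compound 3 (0.79 log units; beyond the scatter), beyond the scatter, and the other is a step that the two limits leave unreadable from compound 1 to compound 3, which cannot be read. Neither introduces oxan-3-yl, and compound 2 alone gives a number, so no step beyond the scatter is expected in this assay. The estimated step is a step that the limit leaves unreadable from compound 3 to compound 4. For compound 4 the expected value is 160 ug/mL, with an estimated range of 90 ug/mL to 260 ug/mL.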

Compound 4, solubility: >= 131 ug/mL
Compound 4 ended at the assay's limit (the forecaster's own chance of this, stated with the estimate: 70%); the middle value lies beyond the limit too.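

In this assay compound 4 gives >= 131 ug/mL, which is a limit and not a number: the limit of >= 131 ug/mL in this assay, at which 1 of the 4 values shown sits.

Oxan-3-yl on a saturated chain carbon bound to an aromatic nitrogen, in place of 4-methylphenyl, gives an at least 5.4-fold higher number from compound 2 to compound 4 (0.73 log units; beyond the scatter), so a ring with a hetero atom also reaches a limit, as cyclohexyl does in compound 3. The steps to compound 4 from compound 3 and from compound 1 cannot be read.

On these data alone, how oxan-3-yl truly ranks against cyclohexyl or 4-methoxyphenyl therefore stays open. Also open, as far as these compounds go, is whether a piperidin-4-yl ring, or a longer chain ending in a carboxylic acid, would reach a limit at this place.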